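Phenyl for cyclohexyl on the sulfonyl of compound 3

A few compounds are considered here, and "the series" means these few. Any claim that something is new, unique, unknown or untested is made for them only; others in the source may bear on it.

Measured in an ADME assay on HEK293 cells (Homo sapiens) for cytotoxicity, read by MTT assay, with a stated time of 48 h; a lower number here means a stronger inhibitor, a higher number a weaker inhibitor:
Compound 1 `COc1ccc(-c2cn3cc(C4=CCN(C(=O)c5ccccc5C(F)(F)F)CC4)ccc3n2)cc1OC`: 82900 nM
Compound 2 `COc1ccc(-c2cn3cc(C4=CCN(C(=O)C5CCCCC5)CC4)ccc3n2)cc1OC`: 72100 nM
Compound 3 `COc1ccc(-c2cn3cc(C4=CCN(S(=O)(=O)C5CCCCC5)CC4)ccc3n2)cc1OC`: 75000 nM

Compound 3 sits with the other two inside one band: a 1.0-fold higher number from compound 2 to compound 3 (0.02 log units; within the scatter), and a 1.1-fold lower number from compound 1 to compound 3 (0.04 log units; within the scatter). Compound 4 `COc1ccc(-c2cn3cc(C4=CCN(S(=O)(=O)c5ccccc5)CC4)ccc3n2)cc1OC` differs from compound 3 by phenyl in place of cyclohexyl on a sulfonyl sulfur. Two earlier steps bear on this. Exchanging the ring on the same carbonyl, a 1.1-fold lower number from compound 1 to compound 2 (0.06 log units; within the scatter), and exchanging carbonyl for sulfonyl under the same cyclohexyl, a 1.0-fold higher number from compound 2 to compound 3 (0.02 log units; within the scatter); neither moved this assay beyond the scatter. An aromatic ring in place of cyclohexyl on the sulfonyl is therefore expected to give no step beyond the scatter, no change at the digits printed from compound 3 to compound 4 (within the scatter). Compound 4 is estimated at 75000 nM, within 40000 nM to 140000 nM.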

Compound 4, half-maximal inhibitory concentration: 65600 nM
Compound 4: the middle estimate sits 1.1-fold (0.06 log units) above what was measured; the measured number falls inside the stated range.
By their numbers in this assay, from the lowest: compounds 4, 2, 3 and 1 (each within the scatter of the next).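

In this assay, phenyl in place of cyclohexyl on the sulfonyl sulfur gives no step beyond the scatter (a 1.1-fold lower number from compound 3 to compound 4 (0.06 log units; within the scatter)). The two wider exchanges on the ring amine nitrogen also stay within it (a 1.1-fold lower number from compound 2 to compound 4 (0.04 log units; within the scatter); a 1.3-fold lower number from compound 1 to compound 4 (0.10 log units; within the scatter)), so an aromatic ring on the sulfonyl joins the other three groups in one band. Nothing available explains this flatness.

On these data alone, whether an amine or a carboxylic acid on the phenyl ring would shift the number remains open. So does the effect of a longer chain in place of the ring on the sulfonyl.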